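Swapping a thiophene for a furan on a nucleoside core

The source may report more compounds than this note shows. Statements on the series, on what has been measured and on what is new or still open speak of the compounds shown alone.

Of the compounds shown here, three have been tested in a functional assay on HCT-116 cells (Homo sapiens), read by MTT assay, with a stated time of 72 h (on this read-out higher numbers stand for weaker inhibition and lower numbers for stronger inhibition), and a fourth awaits its turn. Compound 1 `COc1nc(N)nc2c1c(-c1cccs1)cn2[C@@H]1O[C@H](CO)[C@@H](O)[C@H]1O` reaches only the limit of the assay, giving > 20000 nM in this assay. Compound 3 `COc1nc(N)nc2c1c(-c1ccoc1)cn2[C@@H]1O[C@H](CO)[C@@H](O)[C@H]1O` likewise ends at a limit, giving > 20000 nM. The difference between compound 1 and compound 3 is furan-3-yl in place of thiophen-2-yl on an aromatic carbon, and the step that the two limits leave unreadable from compound 1 to compound 3 cannot be sized, since (the limit of > 20000 nM in this assay, at which 2 of the 3 values shown sit). Going by the values given here, compound 2 `Nc1nc2c(c(-c3cccs3)cn2[C@@H]2O[C@H](CO)[C@@H](O)[C@H]2O)c(=O)[nH]1` is the one compound with a number, giving 19800 nM in this assay. The difference between the cores of compound 1 and compound 2 is not broken down here. Compound 4 `Nc1nc2c(c(-c3ccoc3)cn2[C@@H]2O[C@H](CO)[C@@H](O)[C@H]2O)c(=O)[nH]1` differs from compound 2 by the same change, (furan-3-yl in place of thiophen-2-yl on an aromatic carbon). Because compound 2 gives 19800 nM and the matching step that the two limits leave unreadable from compound 1 to compound 3 is unreadable, compound 4 is expected near 22000 nM. That expectation means a step of about a 1.1-fold higher number from compound 2 to compound 4 (0.05 log units; within the scatter).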

Compound 4, half-maximal inhibitory concentration: 17600 nM
Compound 4: the middle estimate sits 1.3-fold (0.10 log units) above what was measured; the measured number falls inside the stated range.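

In this assay, furan-3-yl in place of thiophen-2-yl gives a 1.1-fold lower number from compound 2 to compound 4 (0.05 log units; within the scatter), so on this core the two groups cannot be told apart. Going by these compounds alone, the same change on the other core, from compound 1 to compound 3, cannot be read, because both ends are limits of the assay and not numbers: the limit of > 20000 nM in this assay, at which 2 of the 4 values shown sit. This leaves only one readable step, which does not show whether the change behaves alike on both cores.

The compounds shown leave open how an amine, a carboxylic acid or a longer carbon chain would read in this assay at the same place on the ring. Going by these compounds, whether any of these would give a clearly lower number than compound 4 at 17600 nM also remains open.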